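Notes on the hydroxy step in the series

The compounds below may be only part of what the source reports. "The series", "measured", "known", "first", "only" and "open" are said of these compounds alone.

Compound 1 `COc1ccc(C2CC(Nc3nc4ccc([N+](=O)[O-])cc4s3)=NN2C(C)=O)cc1` and compound 2 `COc1ccc(C2CC(Nc3nc4ccc([N+](=O)[O-])cc4s3)=NN2C(C)=O)cc1O` differ by hydroxy in place of hydrogen on an aromatic carbon. In a functional assay on the whole organism (Hindlimb, strain albino) with Mus musculus as the target, in the maximal electroshock model, with a stated time of 0.5 h (on this read-out higher numbers stand for an effect only at larger amounts of compound and lower numbers for an effect already at smaller amounts), compound 1 gives 145 umol/kg, and compound 2 gives 178 umol/kg; the step is a 1.2-fold higher number from compound 1 to compound 2 (0.09 log units; within the scatter). Compound 3 `COc1ccc(C2CC(Nc3nc4ccccc4s3)=NN2C(C)=O)cc1` carries another core, and the difference between the two cores is hydrogen in place of nitro on an aromatic carbon. In this assay compound 3 gives 226 umol/kg, a step of a 1.6-fold higher number from compound 1 to compound 3 (0.19 log units; within the scatter) from the nitro-bearing core. Compound 4 `COc1ccc(C2CC(Nc3nc4ccccc4s3)=NN2C(C)=O)cc1O` has not been measured in this assay. It differs from compound 3 by hydroxy in place of hydrogen on an aromatic carbon, the same change as from compound 1 to compound 2, with the same surroundings of the place in both cases, so there is one measured example of this change to lean on. Because a 1.2-fold higher number from compound 1 to compound 2 (0.09 log units; within the scatter) was within the scatter, a step of similar size is expected on the second core as well. For compound 4 the expected step is a 1.2-fold higher number from compound 3 to compound 4 (0.08 log units; within the scatter). The estimate for compound 4 in this assay is 270 umol/kg, with a range from 150 umol/kg to 500 umol/kg, the upper part of the range allowing that the second core may not carry the change the same way.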

Compound 4, dose for half-maximal effect: 259 umol/kg
Compound 4: middle estimate off by 1.0-fold (0.02 log units), on the high side, within the range that was stated.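

In this assay the hydroxy change on the core without nitro gives a 1.1-fold higher number from compound 3 to compound 4 (0.06 log units; within the scatter), and it matches the step seen on the nitro-bearing core: the same change on two cores in this assay, a 1.2-fold higher number (0.09 log units; within the scatter) from compound 1 to compound 2 and a 1.1-fold higher number (0.06 log units; within the scatter) from compound 3 to compound 4, 1.1-fold (0.03 log units) apart, within the scatter of two such steps.
The loss of nitro, read on the hydroxy-bearing pair, gives a 1.5-fold higher number from compound 2 to compound 4 (0.16 log units; within the scatter), and it matches the step read on the pair without hydroxy: the same change on two cores in this assay, a 1.6-fold higher number (0.19 log units; within the scatter) from compound 1 to compound 3 and a 1.5-fold higher number (0.16 log units; within the scatter) from compound 2 to compound 4, 1.1-fold (0.03 log units) apart, within the scatter of two such steps.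
This shows that both changes carry from one core to the other in these four compounds, but every step stays within the scatter, so the agreement is among small steps only and, with a single pair on each side, shows neither an additive rule for the wider series nor how a change with a step beyond the scatter would carry.

Going by these compounds, whether an amine or a carboxylic acid in the place of the hydroxy would move the number beyond the scatter stays open. So does the outcome of a longer chain in place of the methoxy group, on either core.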